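Shortening the Chain Beside the Sulfur in a Thioether Series

The source may hold more compounds than are shown below. What is called first, only, known or untested is meant among the compounds shown, and "the series" means these compounds.

Compound 1 `Cn1c(=O)c2c(nc(SCCc3ccc(F)cc3)n2C)n(C)c1=O` is the weakest of three thioethers measured so far in an assay on microsomes for inhibition of Amine oxidase [flavin-containing] B (Homo sapiens), read by fluorescence and spectrophotometry, with a stated time of 20 min; a lower number here means a stronger inhibitor, a higher number a weaker inhibitor; compound 1 gives 71 nM, the highest number of the three. Compound 2 `COc1ccc(CCSc2nc3c(c(=O)n(C)c(=O)n3C)n2C)cc1` gives 23 nM in this assay, and compound 3 `Cn1c(=O)c2c(nc(SCCCc3ccc(Cl)cc3)n2C)n(C)c1=O` gives 61 nM. Swapping the halogen for a methoxy group gave a 3.1-fold lower number from compound 1 to compound 2 (0.49 log units; beyond the scatter), a step beyond the scatter, while lengthening the chain and moving from fluorine to chlorine gave only a 1.2-fold lower number from compound 1 to compound 3 (0.07 log units; within the scatter), a step within the scatter; between the two substituted analogues the difference was a 2.7-fold higher number from compound 2 to compound 3 (0.42 log units; beyond the scatter).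

Compound 4 `Cn1c(=O)c2c(nc(SCc3cccc(Br)c3)n2C)n(C)c1=O` has not yet been measured. Relative to compound 1 the change is 3-bromophenyl in place of 4-fluorobenzyl on a saturated chain carbon bound to a sulfur, so the chain between the sulfur and the aromatic ring becomes one carbon shorter and the halogen changes and moves round the ring. Among the compounds with values here, no measured step makes exactly this change. The nearest guide is the step from compound 1 to compound 3, where a change in chain length together with a change of halogen stayed within the scatter, whereas only the methoxy substitution in compound 2 moved the number clearly. A step near the scatter in this assay is therefore expected for compound 4, in either direction.

Compound 4 is estimated at 85 nM, with a range from 30 nM to 250 nM, which is expected to correspond to a 1.2-fold higher number from compound 1 to compound 4 (0.08 log units; within the scatter).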

Compound 4, half-maximal inhibitory concentration: 199 nM
Compound 4: middle estimate off by 2.3-fold (0.37 log units), on the low side; measured number inside the range.
By their numbers in this assay, from the lowest: compound 2; then compounds 3 and 1 (each within the scatter of the next); then compound 4.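

In this assay, the exchange at this saturated chain carbon bound to a sulfur gives a 2.8-fold higher number from compound 1 to compound 4 (0.45 log units; beyond the scatter), the first step away from compound 1 that raises the number beyond the scatter. The earlier change at the same place, a 1.2-fold lower number from compound 1 to compound 3 (0.07 log units; within the scatter), stayed within the scatter, so compound 4 shows that this part of compound 1 does not accept every change without a loss of inhibition. No measurement here explains the rise, so it cannot be assigned to any one feature of the change.

As far as these compounds go, the shorter chain, the exchange of fluorine for bromine and the new ring position all arrive together in compound 4, so their separate contributions remain open; a 4-bromobenzyl group at this place would keep the chain length of compound 1 and alter only the halogen, while a 3-fluorophenyl group would keep the shorter chain and the new ring position but restore the fluorine. Also open, from the compounds shown here alone, is how the shorter chain would behave with a 4-methoxyphenyl group, or with an amine or a carboxylic acid on the ring.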